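Swapping a pyrimidinyl arm for a trifluoromethylphenyl arm

A few compounds are considered here, and "the series" means these few. Any claim that something is new, unique, unknown or untested is made for them only; others in the source may bear on it.

The account concerns two acids built on the same core, with a third, unmeasured one judged against them. Going by the values given here, compound 1 `Cc1nn(-c2nc(-c3ccc(Cl)c(Cl)c3)c(SC(C)C)s2)c(C(=O)O)c1-c1cncnc1` is the only member of this small set for which a number exists in a functional assay on BJAB cells (Homo sapiens) for antiproliferative activity, with a stated time of 4 days; on this read-out lower numbers stand for an effect already at smaller amounts and higher numbers for an effect only at larger amounts of compound: in this assay compound 1 gives 22000 nM. Compound 2 `Cc1c(-c2cc(Cl)cc(Cl)c2)c(C(=O)O)nn1-c1nc(-c2ccc3nccn3c2)c(SC(C)C)s1` carries different aryl groups on both ends of the core, and in this assay compound 2 is reported only as "not active" (no number reported), with no number to set beside compound 1. Compound 1 therefore stands alone as the sole quantified point, and nothing in the data ranks it against anything else.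

Compound 3 `Cc1nn(-c2nc(-c3ccc(Cl)c(Cl)c3)c(SC(C)C)s2)c(C(=O)O)c1-c1cccc(C(F)(F)F)c1` differs from compound 1 in one place: 3-(trifluoromethyl)phenyl in place of pyrimidin-5-yl on an aromatic carbon. Among the compounds with values here, no pair of measured compounds spans a single change of this kind, so there is no measured step to lean on. With one weak number and one inactive neighbour, the step in this assay is expected to be small, if any, and the estimate is that it falls within the scatter or leans modestly toward an effect at smaller amounts, a 1.8-fold lower number from compound 1 to compound 3 (0.26 log units; within the scatter). Compound 3 is accordingly expected to give about 12000 nM in this assay, within a range of 2500 nM to 50000 nM.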

Compound 3, half-maximal effective concentration: 22000 nM
Compound 3: the middle estimate sits 1.8-fold (0.26 log units) below what was measured; the range from low to high includes it.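

In this assay, exchanging pyrimidin-5-yl for 3-(trifluoromethyl)phenyl on the aromatic carbon next to the ring atom that bears a carboxy group gives no change at the digits printed from compound 1 to compound 3 (within the scatter). Going by these compounds alone, this is the first measured step at this position, and it shows that the two arms cannot be told apart in this read-out, even though the entering arm counts 10 heavy atoms against 6, has a ring of carbon only, and has 0 hydrogen-bond acceptors against 2. No measurement at hand offers an explanation for this result.

The compounds shown leave open whether any group on this carbon would move the read-out, for instance a plain phenyl, a morpholine ring or an aminomethyl group, since two arms with one shared value mark out only a narrow part of what could stand there. They also leave open whether the same exchange would give the same result on a core carrying a primary amide in place of the carboxy group.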